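A few compounds are considered here, and "the series" means these few. Any claim that something is new, unique, unknown or untested is made for them only; others in the source may bear on it.

Compound 2 `O=C(O)c1ccc2noc(-c3ccc(NC(=O)C4CCCC4)cc3)c2c1` gives 240 nM in an assay for inhibition of inositol hexakisphosphate kinase 3 (Homo sapiens), read by colorimetric assay, coupled enzyme assay and malachite green, with a stated time of 120 min, in the presence of a further agent that is not named here (on this read-out higher numbers stand for weaker inhibition and lower numbers for stronger inhibition), the higher of the two numbers measured, though its neighbour compound 1 `CC(C)C(=O)Nc1ccc(-c2onc3ccc(C(=O)O)cc23)cc1` at 210 nM sits within the scatter of it, as the change a 1.1-fold higher number from compound 1 to compound 2 (0.06 log units; within the scatter) shows. Compound 3 `O=C1CCC(C(=O)Nc2ccc(-c3onc4ccc(C(=O)O)cc34)cc2)CN1` differs from compound 2 in one place: a group of 7 heavy atoms (5 carbon, 1 nitrogen, 1 oxygen; one six-membered non-aromatic ring with 1 hetero atom) in place of a group of 5 heavy atoms (5 carbon; one five-membered non-aromatic ring of carbon only), on a carbonyl carbon. Within the data shown here, only that single step on the same carbonyl carbon bears on this change, and it was within the scatter, so no firm pull in either direction is expected; a modest step of a 1.5-fold higher number from compound 2 to compound 3 (0.16 log units; within the scatter) toward a higher number is estimated. Compound 3 is expected to give about 350 nM, within 120 nM to 1000 nM.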

Compound 3, half-maximal inhibitory concentration: 1650 nM
For compound 3 the middle estimate is 4.7-fold (0.67 log units) below the measured one, outside the stated range (above it).
By their numbers in this assay, from the lowest: compounds 1 and 2 (each within the scatter of the next); then compound 3.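

Until now, cyclopentyl and isopropyl on this carbonyl carbon could not be told apart, so carbon-only groups gave no sign that the position matters. Among these compounds, the six-membered ring with its hetero atom, which brings a hydrogen-bond donor and acceptor, is the first group here to move the number beyond the scatter, with a 6.9-fold higher number from compound 2 to compound 3 (0.84 log units; beyond the scatter) and a 7.9-fold higher number from compound 1 to compound 3 (0.90 log units; beyond the scatter), both toward weaker inhibition. Nothing available here gives a cause for this shift. Still open, from the compounds shown here alone, is whether the ring's nitrogen and oxygen or the six-membered ring itself accounts for the change. A cyclohexyl group on the same carbonyl carbon would separate the two.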